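The source may report more compounds than this note shows. Statements on the series, on what has been measured and on what is new or still open speak of the compounds shown alone.

Measured so far:
compound 1 `O=C(CO[N+](=O)[O-])Nc1ccc(C(=O)/C=C/c2ccc(Cl)cc2)cc1`, in a functional assay on the whole organism (strain albino) for inhibition, with Rattus norvegicus as the target, read by paw edema, with stated times of 30 min and 5 h, at a dose of 100 mg/kg by the oral route (on this read-out higher numbers stand for more inhibition at the one dose given (going by the name of the read-out) and lower numbers for less inhibition), compound 1 gives 60%
compound 2 `COc1ccc(/C=C/C(=O)c2ccc(NC(=O)CO[N+](=O)[O-])cc2)cc1`, compound 2 gives 46%
compound 3 `O=C(CO[N+](=O)[O-])Nc1ccc(C(=O)/C=C/c2ccco2)cc1`, compound 3 gives 39%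

Compound 2 stands second highest of these three. The step from compound 1 to compound 2 is a number 14 percentage points lower from compound 1 to compound 2 (beyond the scatter), while the step to compound 3 is a number 7 percentage points lower from compound 2 to compound 3 (within the scatter), so compound 2 and compound 3 cannot be ranked against each other.

Compound 4 `COc1ccc(/C=C/C(=O)c2ccc(NC(=O)C(C)O[N+](=O)[O-])cc2)cc1` differs from compound 2 by methyl in place of hydrogen on a saturated chain carbon bound to a carbonyl carbon and an oxygen on an unsaturated carbon. For the measured compounds named here, none of the measured steps touches this part of the shared core; all of them swap the ring at the far end of the chain, and they are at most modest. For this assay, then, no step beyond the scatter is expected: no change at the digits printed from compound 2 to compound 4 (within the scatter). Compound 4 is estimated at 46%, with a range from 30% to 60%.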

Compound 4, a percentage reported as inhibition, in the whole organism at one dose (the size of the read-out at that dose, not a potency): 35%
For compound 4 the middle estimate is 11 percentage points above the measured one, within the range that was stated.
By their numbers in this assay, from the lowest: compounds 4, 3 and 2 (each within the scatter of the next, the first and the last beyond it); then compound 1.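

For the compounds shown here, the earlier steps all swapped the ring at the far end of the chain, so this is the first sign that the shared core also matters in this assay. Going from (nitrooxy)methyl to 1-(nitrooxy)ethyl adds just one carbon, yet it gives a number 11 percentage points lower from compound 2 to compound 4 (beyond the scatter) and so is not a silent change. Nothing shown explains this drop. Still open, as far as these compounds go, is what an ethyl group or an amine would do on this carbon. So is whether the same methyl has a similar effect with the 4-chlorophenyl end of compound 1.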